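Hydroxyl in place of acetoxy: stability in buffer

A few compounds are considered here, and "the series" means these few. Any claim that something is new, unique, unknown or untested is made for them only; others in the source may bear on it.

Measured compounds:
Compound 1, `CC(C)C(=O)OCOC(=O)C1=C(S[C@@H]2CN[C@H](C(=O)Nc3cccc(C(=O)OCOC(=O)C(C)C)c3)C2)[C@H](C)[C@@H]2[C@@H]([C@@H](C)O)C(=O)N12`: in a physicochemical assay for metabolic stability, read by LC-MS, in phosphate buffer, with a stated time of 3 h, at pH 7.4, tested at 50 uM (on this read-out lower numbers stand for a less stable compound and higher numbers for a more stable compound), compound 1 gives > 95%, which is a limit of the assay and not a number.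
Compound 2, `CC(OC(=O)C1=C(S[C@@H]2CN[C@H](C(=O)Nc3cccc(C(=O)OC(C)OC(=O)C(C)(C)C)c3)C2)[C@H](C)[C@@H]2[C@@H]([C@@H](C)O)C(=O)N12)OC(=O)C(C)(C)C`: compound 2 gives > 95%, again a limit.
Compound 3, `CCOC(=O)C1=C(S[C@@H]2CN[C@H](C(=O)Nc3cccc(C(=O)OCC)c3)C2)[C@H](C)[C@@H]2[C@@H]([C@@H](C)OC(C)=O)C(=O)N12`: compound 3 gives > 95%, also a limit.

Compound 3 therefore stands at the limit of this assay, not at a measured number, and the same holds for the two other compounds shown (the limit of > 95% in this assay, at which 3 of the 3 values shown sit). Going by the values given here, with every value at the limit, no order among compounds 1, 2 and 3 can be read, and no step between measured compounds is available to calibrate the next change.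

Compound 4, `CCOC(=O)C1=C(S[C@@H]2CN[C@H](C(=O)Nc3cccc(C(=O)OCC)c3)C2)[C@H](C)[C@@H]2[C@@H]([C@@H](C)O)C(=O)N12`, is not yet measured. It differs from compound 3 in one place: hydrogen in place of acetyl on an oxygen on a saturated carbon, or read one bond further out, 1-acetoxyethyl to 1-hydroxyethyl.

Nothing in the measured set shows a step in this assay, so the step expected from compound 3 to compound 4, a step that the limit leaves unreadable from compound 3 to compound 4, is none beyond the usual scatter. Compound 4 is accordingly estimated at 96%, with a range from 88% to 100%, and is expected most likely to be reported again as a limit rather than as a number.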

Compound 4, percent of the compound remaining: > 95%
Compound 4: only a limit was reported; the forecaster's own chance of this, stated with the estimate: 80%; the middle value does not contradict the limit.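

In this assay no new step can be read from compound 3 to compound 4, because both results are limits of the assay and not numbers: the limit of > 95% in this assay, at which 4 of the 4 values shown sit.

The compounds shown leave open whether 1-acetoxyethyl and 1-hydroxyethyl differ at all in this read-out, since no compound here gives a value short of the limit.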